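This account rests on a few compounds, and the source may have more. Where it says the series, first, only, none or still open, it means among the compounds named here.

Of the compounds shown here, three have so far been tested in a functional assay on the whole organism (Tail, strain ICR) with Mus musculus as the target, in the tail flick test, with a stated time of 60 min, at a dose of 25 umol/kg by the oral route; a lower number here means a weaker effect, a higher number a stronger effect of the compound at the dose given. Compound 2 `CC(C)[C@H](NC(=O)CN(c1ncnc2c1ncn2C1CCCCO1)C1CC1)C(=O)OCc1ccccc1` gives 34.9% there. Its nearest neighbour on these numbers is compound 1 `C[C@@H](O)[C@H](NC(=O)CN(c1nc(Cl)nc2[nH]cnc12)C1CC1)C(=O)O`, which gives 30.1%, a gap within the usual scatter of repeated measurements. The furthest is compound 3 `O=C(CN(c1nc(Cl)nc2[nH]cnc12)C1CC1)N[C@@H](CO)C(=O)O`, which gives 39.8%, and that gap is also within the scatter. Among the measured compounds shown here, compound 1 and compound 3 differ in one place, and the one measured step, a number 9.7 percentage points higher from compound 1 to compound 3 (within the scatter), is itself within the scatter.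

Compound 4 `O=C(CN(c1ncnc2c1ncn2C1CCCCO1)C1CC1)N[C@@H](CC(=O)OCc1ccccc1)C(=O)OCc1ccccc1` has not yet been measured. It is derived from compound 2 by one change: (benzyloxycarbonyl)methyl in place of isopropyl on a saturated chain carbon bound to an amide-type nitrogen and a carbonyl carbon.

For the measured compounds named here, none of the measured steps involves this kind of change, so no direct precedent exists. What the three measured compounds show is that quite different side chains and cores all land within the scatter of one another. On that basis, the step of a number 0.1 percentage points higher from compound 2 to compound 4 (within the scatter) is expected to stay within the scatter, with no clear direction. Compound 4 is therefore estimated to give 35%, in a range from 20% to 50%.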

Compound 4, a percentage reported as activity, at one dose (the size of the read-out at that dose, not a potency): 38.2%
Beside the measured number, compound 4's estimate is 3.2 percentage points below it, within the range that was stated.
By their numbers in this assay, from the lowest: compounds 1, 2, 4 and 3 (each within the scatter of the next).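

In this assay the step of a number 3.3 percentage points higher from compound 2 to compound 4 (within the scatter) shows that this position, on a saturated chain carbon bound to an amide-type nitrogen and a carbonyl carbon, can take a far larger group without the read-out leaving the scatter. Isopropyl has 3 heavy atoms and no ring, while (benzyloxycarbonyl)methyl has 11 heavy atoms and brings a six-membered aromatic ring and hydrogen-bond acceptors, neither of which isopropyl has. Among the compounds shown here, the one earlier step only exchanged a methyl for a hydrogen, so this is the first sign that a large change in the side chain can leave the number within the scatter, and nothing at hand accounts for that result.

For the compounds shown here, only two groups at this position can be compared directly on this core, so it remains open whether an amine or a longer chain of saturated carbons there would also stay within the scatter. Each number also comes from one dose at one time point, so a similar read-out here does not establish that compound 2 and compound 4 have the same potency.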